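A few compounds are considered here, and "the series" means these few. Any claim that something is new, unique, unknown or untested is made for them only; others in the source may bear on it.

Measured so far in a functional assay on ACHN cells (Homo sapiens) for inhibition, read by sulforhodamine B assay, with a stated time of 48 h, tested at 10 uM; on this read-out lower numbers stand for a stronger effect and higher numbers for a weaker effect at the one concentration tested:
compound 1 `COc1cc2cc(Oc3ccc(NC(=O)Nc4ccccc4)cc3)c(C)nc2cc1OC` gives 84.5%
compound 2 `COc1cc2cc(Oc3ccc(NC(=O)Nc4ccc(C)cc4)cc3)c(C)nc2cc1OC` gives 103%

Compound 2 holds the higher of the two numbers; its nearest neighbour is compound 1, the step between them being a number 18.5 percentage points higher from compound 1 to compound 2 (beyond the scatter). Compound 3 `COc1cc2cc(Oc3ccc(NC(=O)Nc4ccc(C(F)(F)F)cc4)cc3)c(C)nc2cc1OC` differs from compound 2 by trifluoromethyl in place of methyl on an aromatic carbon. Going by the values given here, no measured step covers this exchange; the single step known, methyl for hydrogen at the same position, was modest and towards a weaker effect. Compound 3 is therefore expected to show a step of a number 8 percentage points lower from compound 2 to compound 3 (within the scatter), not beyond the scatter. The estimate for compound 3 in this assay is 95%, range 75% to 115%.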

Compound 3, a percentage reported as activity, at one concentration (the size of the read-out at that concentration, not a potency): 56.1%
Estimate against measurement, compound 3: 38.9 percentage points above, outside the stated range (below it).
By their numbers in this assay, from the lowest: compound 3; then compound 1; then compound 2.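

In this assay trifluoromethyl in place of methyl gives a number 46.9 percentage points lower from compound 2 to compound 3 (beyond the scatter) and trifluoromethyl in place of hydrogen gives a number 28.4 percentage points lower from compound 1 to compound 3 (beyond the scatter) at the same position. This position therefore moves the number in both directions, depending on the group: methyl in compound 2 goes towards a weaker effect and trifluoromethyl in compound 3 towards a stronger one. Nothing available bears on the cause of this difference.

From the compounds shown here alone, whether a chlorine, a methoxy group or a nitrile at this position would follow trifluoromethyl or methyl stays open. Each compound has a reading at a single concentration only; the numbers tell of a stronger or weaker effect at that concentration and of nothing beyond it.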